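This account rests on a few compounds, and the source may have more. Where it says the series, first, only, none or still open, it means among the compounds named here.

In a functional assay on HO8910 cells (Homo sapiens) for inhibition, read by MTT assay, with a stated time of 24 h, tested at 1 ug/mL (a higher number here means more inhibition of growth at the concentration tested, a lower number less inhibition of growth), compound 1 (`O=C(CCCCC(S)CCS)Nc1ccc(Cl)cc1`) gives 2.81% and compound 2 (`O=C(CCCCC(S)CCS)Nc1ccc([N+](=O)[O-])c(C(F)(F)F)c1`) gives 1.17%. These two values lie within the scatter of each other, and both show little inhibition of growth. Compound 3 (`O=C(CCCCC(S)CCS)Nc1ccc([N+](=O)[O-])cc1`) differs from compound 2 by hydrogen in place of trifluoromethyl on an aromatic carbon, ortho to a nitro group. Among the measured compounds shown here, no measured pair shows what a single change does in this assay, so no step beyond the scatter is expected. The expected step, a number 1.8 percentage points higher from compound 2 to compound 3 (within the scatter), is small. Compound 3 is estimated at 3%, with a range of 0% to 12%.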

Compound 3, percent growth inhibition at one concentration: 0.76%
Beside the measured number, compound 3's estimate is 2.2 percentage points above it, and the stated range covers the measured number.
By their numbers in this assay, from the lowest: compounds 3, 2 and 1 (each within the scatter of the next).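

In this assay, among the compounds shown here, hydrogen in place of trifluoromethyl on an aromatic carbon, ortho to a nitro group, gives a number 0.4 percentage points lower from compound 2 to compound 3 (within the scatter), the first one-place comparison at this position. Nitro in place of chloro on an aromatic carbon gives a number 2.1 percentage points lower from compound 1 to compound 3 (within the scatter), so neither change separates the compounds, and all three show little inhibition of growth. No measurement at hand bears on this result.

Going by these compounds, whether an amine or a carboxylic acid on this aromatic carbon would raise inhibition of growth stays open. So does the effect of a longer chain on the shared core.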